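Amide Aryl Swaps in a Quinoline Antiproliferative Series

This account rests on a few compounds, and the source may have more. Where it says the series, first, only, none or still open, it means among the compounds named here.

Measured compounds:
compound 1, `CCN1CCN(c2cc(C)c3cc(NC(=O)c4ccccc4F)ccc3n2)CC1`, 32600 nM;
compound 2, `CCN1CCN(c2cc(C)c3cc(NC(=O)c4ccc(Cl)cc4)ccc3n2)CC1`, 1530 nM;
compound 3, `CCN1CCN(c2cc(C)c3cc(NC(=O)c4cc(Cl)cc(Cl)c4)ccc3n2)CC1`, 6090 nM.

These three share one core and differ only in the aryl group on the carbonyl carbon of the amide. In a functional assay on MCF7 cells (Homo sapiens) for antiproliferative activity, read by MTT assay, with a stated time of 72 h (on this read-out lower numbers stand for stronger inhibition and higher numbers for weaker inhibition), compound 3 stands second highest of the three numbers: the step of a 4.0-fold higher number from compound 2 to compound 3 (0.60 log units; beyond the scatter) was modest, while a 5.4-fold lower number from compound 1 to compound 3 (0.73 log units; beyond the scatter) and a 21-fold lower number from compound 1 to compound 2 (1.33 log units; beyond the scatter) show that moving away from 2-fluorophenyl helped most. Compound 4, `CCN1CCN(c2cc(C)c3cc(NC(=O)c4ccc(F)c(F)c4)ccc3n2)CC1`, is not yet measured; its change is 3,4-difluorophenyl in place of 3,5-dichlorophenyl on a carbonyl carbon. The steps 2>3 and 1>3 bear on this, since both concern where and which halogens sit on the phenyl. A step in either direction of modest size seems plausible, so compound 4 is expected near compound 3, perhaps somewhat lower, with a 1.7-fold lower number from compound 3 to compound 4 (0.24 log units; within the scatter), giving an estimate of 3500 nM with a range from 1000 nM to 12000 nM.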

Compound 4, half-maximal inhibitory concentration: 5230 nM
Estimate against measurement, compound 4: 1.5-fold (0.17 log units) below, and the stated range covers the measured number.
By their numbers in this assay, from the lowest: compound 2; then compounds 4 and 3 (each within the scatter of the next); then compound 1.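

In this assay the step of a 1.2-fold lower number from compound 3 to compound 4 (0.07 log units; within the scatter) lies within the scatter, so 3,5-dichlorophenyl and 3,4-difluorophenyl read alike at this position, although the halogen and its placement both change. Compound 4 still stands apart from the other two aryl amides, as a 3.4-fold higher number from compound 2 to compound 4 (0.53 log units; beyond the scatter) and a 6.2-fold lower number from compound 1 to compound 4 (0.79 log units; beyond the scatter) show, which leaves compound 2 alone with the lowest of the four numbers. Nothing measured here offers a reason for these differences. The compounds shown leave open how a phenyl carrying an amine or a carboxylic acid would read at this position, and whether a saturated cyclohexyl group could replace the aromatic ring.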